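The source may report more compounds than this note shows. Statements on the series, on what has been measured and on what is new or still open speak of the compounds shown alone.

Measured compounds in a functional assay on HEp-2 cells (Homo sapiens) for antiproliferative activity, read by MTT assay, with a stated time of 72 h; a lower number here means a stronger inhibitor, a higher number a weaker inhibitor:
compound 1, `CC(C)N(C(=S)SCc1coc2ccccc2c1=O)C(C)C`: 3000 nM
compound 2, `CN1CCN(C(=S)SCc2coc3ccccc3c2=O)CC1`: 2400 nM
compound 3, `O=c1c(CSC(=S)N2CCCCC2)coc2ccccc12`: 390 nM

Of the three numbers, compound 3 holds the lowest, and its gaps to both other compounds lie beyond the scatter. Compound 4, `O=c1c(CSC(=S)N2CCCC2)coc2ccccc12`, differs from compound 3 in one place: pyrrolidin-1-yl in place of piperidin-1-yl on a thiocarbonyl carbon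

Going by the values given here, two measured steps bear on this change, since both alter the amine on the thiocarbonyl carbon while the shared core is kept: a 7.7-fold lower number from compound 1 to compound 3 (0.89 log units; beyond the scatter) and a 6.2-fold lower number from compound 2 to compound 3 (0.79 log units; beyond the scatter), each a modest fall in the number toward compound 3. The step of a 1.3-fold lower number from compound 1 to compound 2 (0.10 log units; within the scatter) shows that the two other amines give numbers within the scatter of each other. Among the compounds with values here, no measured step involves pyrrolidin-1-yl, so nothing here shows how the five-membered ring compares with the six-membered one; the data only show that the two departures from piperidin-1-yl both gave higher numbers. The account therefore expects compound 4 to give a number not lower than compound 3, most likely a little higher, but with wide uncertainty. Compound 4 is estimated at 650 nM, within a range from 250 nM to 1700 nM. This corresponds to an expected step of a 1.7-fold higher number from compound 3 to compound 4 (0.22 log units; within the scatter).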

Compound 4, half-maximal inhibitory concentration: 3600 nM
Beside the measured number, compound 4's estimate is 5.5-fold (0.74 log units) below it, and the stated range ends below it.
By their numbers in this assay, from the lowest: compound 3; then compounds 2, 1 and 4 (each within the scatter of the next).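

In this assay, the amine on the thiocarbonyl carbon proves sensitive to ring size: pyrrolidin-1-yl in place of piperidin-1-yl gives a 9.2-fold higher number from compound 3 to compound 4 (0.97 log units; beyond the scatter), so having a non-aromatic ring at this place is not enough to keep the low number of compound 3. The five-membered ring instead joins the two other amines, with a 1.5-fold higher number from compound 2 to compound 4 (0.18 log units; within the scatter) and a 1.2-fold higher number from compound 1 to compound 4 (0.08 log units; within the scatter), leaving the 4-methylpiperazin-1-yl, diisopropylamino and pyrrolidin-1-yl compounds within the scatter of one another and piperidin-1-yl alone apart from all three. Nothing available here offers a measured explanation for this sharp dependence on the amine.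

The compounds shown leave open whether the low number is confined to the six-membered ring, or would also appear with a seven-membered azepan-1-yl ring, a morpholin-4-yl ring or a piperidin-1-yl ring carrying a methyl group. They also leave open how far the result depends on the rest of the molecule, as all four compounds keep the same shared core and the same sulfur on the thiocarbonyl carbon.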